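The source may hold more compounds than are shown below. What is called first, only, known or untested is meant among the compounds shown, and "the series" means these compounds.

This account follows one step within a small set of chalcone-type anilines. Compound 1 `Nc1ccc(C(=O)/C=C/c2ccc(Cl)cc2)cc1` is the starting point. In a functional assay on the whole organism (strain albino) for inhibition, with Rattus norvegicus as the target, read by paw edema, with stated times of 30 min and 2 h, at a dose of 100 mg/kg by the oral route (a lower number here means less inhibition, a higher number more inhibition at the dose given (going by the name of the read-out)), compound 1 gives 50%. Compound 2 `Nc1ccc(C(=O)/C=C/c2ccco2)cc1` gives 38% in this assay, and compound 3 `COc1ccc(/C=C/C(=O)c2ccc(NC(=O)C(C)Br)cc2)cc1` gives 40%. Compound 1 thus stands highest of the three numbers; its gap to compound 3 lies within the usual scatter, so the two cannot be ordered, while its gap to compound 2 lies beyond the scatter.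

The step under consideration leads to compound 4 `CC(O[N+](=O)[O-])C(=O)Nc1ccc(C(=O)/C=C/c2ccc(Cl)cc2)cc1`. Relative to compound 1, the change is a group of 8 heavy atoms (3 carbon, 1 nitrogen, 4 oxygen; no ring) in place of a hydrogen atom, on a nitrogen on an aromatic ring. Compound 3 also carries an amide-type substituent on the ring nitrogen in place of the free amine, and its value sits within the scatter of compound 1. Within the data shown here, no step in this assay between measured compounds is available, so the expectation rests on that comparison alone. A step from compound 1 to compound 4 of a number 5 percentage points lower from compound 1 to compound 4 (within the scatter) is expected, that is, no change beyond the scatter. Compound 4 is estimated at 45%, with a range from 30% to 60%.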

Compound 4, a percentage reported as inhibition, in the whole organism at one dose (the size of the read-out at that dose, not a potency): 55%
Compound 4: the middle estimate sits 10 percentage points below what was measured; the measured number falls inside the stated range.
By their numbers in this assay, from the lowest: compounds 2, 3, 1 and 4 (each within the scatter of the next, the first and the last beyond it).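

Among these compounds, the step gives the first direct reading at this position: on the nitrogen on an aromatic ring of the core of compound 1, a group of 8 heavy atoms without a ring replaces a hydrogen atom with a number 5 percentage points higher from compound 1 to compound 4 (within the scatter) in this assay. A free amine at this position is thus not needed to retain this level of inhibition at the dose given, a point that compound 3 could not settle, since it differs from compound 1 in more than one place. Nothing measured here bears on why the number holds up across this change.

The compounds shown leave open whether a plain acetyl group or a longer chain on the same nitrogen would give a similar number. They also leave open how a hydroxyl group or a bromine atom in place of the nitrate ester would read on this core.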